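The compounds below may be only part of what the source reports. "The series", "measured", "known", "first", "only" and "open" are said of these compounds alone.

The series shares one core, seen in compound 1 `COc1cc(-c2nnc3n2NC(c2cccs2)C(C(=O)c2ccc(F)cc2)S3)cc(OC)c1OC`, compound 3 `COc1cc(-c2nnc3n2NC(c2cccs2)C(C(=O)c2ccc(Cl)cc2)S3)cc(OC)c1OC` and compound 2 `COc1cc(-c2nnc3n2NC(c2ccco2)C(C(=O)C2CC2)S3)cc(OC)c1OC`. In a functional assay on A549 cells (Homo sapiens) for cytotoxicity, read by MTT assay, with a stated time of 48 h (a higher number here means a weaker inhibitor, a lower number a stronger inhibitor), compound 1 gives 45000 nM. In this assay compound 3 gives 20100 nM. For the measured compounds named here, the only single-point step measured, a 2.2-fold lower number from compound 1 to compound 3 (0.35 log units; beyond the scatter), concerns the halogen on the phenyl that sits on the carbonyl carbon. For compound 2 this assay reports no number but a limit, > 100000 nM. Going by the values given here, compound 2 is the one compound sitting at the limit of > 100000 nM in this assay, at which 1 of the 3 values shown sits, so it stands at the weak end of what has been measured in this assay. Compound 4 `COc1cc(-c2nnc3n2NC(c2ccco2)C(C(=O)c2ccc(-c4ccccc4)cc2)S3)cc(OC)c1OC` differs from compound 2 in one place: 4-phenylphenyl in place of cyclopropyl on a carbonyl carbon. Among the compounds with values here, no measured step covers a change of this kind at the carbonyl carbon; the step from compound 1 to compound 3 is a halogen swap on a phenyl already present and is modest. Within the data shown here, the only hint is that compounds 1 and 3, each carrying a substituted phenyl on the carbonyl carbon, return numbers rather than limits in this assay. The expected step is therefore a move from the limit to a measurable number, with wide uncertainty, written as an at least 2.5-fold lower number from compound 2 to compound 4 (0.39 log units; beyond the scatter). Compound 4 is estimated at 40000 nM, in the range 10000 nM to 150000 nM.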

Compound 4, half-maximal inhibitory concentration: > 100000 nM
Compound 4: only a limit was reported (the forecaster's own chance of this, stated with the estimate: 35%); middle value at least 2.5-fold (0.39 log units) away from the limit.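

In this assay compound 4 gives > 100000 nM, which is a limit; compound 2 also has only a limit, so no step can be read between them. Both now sit at the same limit: the limit of > 100000 nM in this assay, at which 2 of the 4 values shown sit.

The compounds shown leave open how 4-phenylphenyl and cyclopropyl on a carbonyl carbon compare in this assay.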